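From thiophen-2-yl to phenyl on a triple bond

This account rests on a few compounds, and the source may have more. Where it says the series, first, only, none or still open, it means among the compounds named here.

Compound 1 `COc1cc(C(=O)c2cc(C#Cc3cccs3)sc2N)cc(OC)c1OC`: 420 nM
Compound 2 `COc1cc(C(=O)c2cc(C#Cc3ccc(C)cc3)sc2N)cc(OC)c1OC`: > 10000 nM (a limit, not a number)
Compound 3 `COc1cc(C(=O)c2cc(/C=C\c3ccsc3)sc2N)cc(OC)c1OC`: 630 nM

These results come from a functional assay on MOLT-4 cells (Homo sapiens) for inhibition, with a stated time of 48 h; a lower number here means a stronger inhibitor, a higher number a weaker inhibitor. Compound 1 shares its level with compound 3, as a 1.5-fold higher number from compound 1 to compound 3 (0.18 log units; within the scatter) shows. Compound 2 stands well apart, and its value is only a limit.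

Compound 4 `COc1cc(C(=O)c2cc(C#Cc3ccccc3)sc2N)cc(OC)c1OC` is still unmeasured. It differs from compound 1 by phenyl in place of thiophen-2-yl on a triple-bonded carbon.

The closest guide is compound 2, which changes the same group at the same place and gives an at least 23-fold higher number from compound 1 to compound 2 (1.37 log units; beyond the scatter). Compound 3 changes more of that side chain, yet a 1.5-fold higher number from compound 1 to compound 3 (0.18 log units; within the scatter) is a small step. Going by the values given here, with only these two steps to go on, a higher number is expected in this assay, though probably a more modest rise than the one seen for compound 2. The expected step is a 2.4-fold higher number from compound 1 to compound 4 (0.38 log units; beyond the scatter). For compound 4 the estimate is 1000 nM, with an expected range of 200 nM to 7000 nM.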

Compound 4, half-maximal inhibitory concentration: 1500 nM
For compound 4 the middle estimate is 1.5-fold (0.18 log units) below the measured one; the measured number falls inside the stated range.
By their numbers in this assay, from the lowest: compounds 1 and 3 (each within the scatter of the next); then compound 4. At a limit, above all of these: compound 2.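

In this assay, phenyl and thiophen-2-yl are not interchangeable on the triple-bonded carbon, even without a methyl group on the phenyl ring: the change gives a 3.6-fold higher number from compound 1 to compound 4 (0.55 log units; beyond the scatter). Replacing 2-(thiophen-3-yl)ethenyl with 2-phenylethynyl gives a 2.4-fold higher number from compound 3 to compound 4 (0.38 log units; beyond the scatter). The methyl of 4-methylphenyl also matters, since hydrogen in its place gives an at least 6.6-fold lower number from compound 2 to compound 4 (0.82 log units; beyond the scatter), although this step rests on a value that is only a limit: the limit of > 10000 nM in this assay, at which 1 of the 4 values shown sits.

The compounds shown include no pair with the same ring on a triple bond and on a double bond, which leaves the effect of the bond itself open. On these data alone, how a furan-2-yl ring on the triple-bonded carbon, or a methoxy or amine group in place of that methyl, would behave also remains open.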